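Nitro for Bromo in a Benzyl Thioether Series

This account rests on a few compounds, and the source may have more. Where it says the series, first, only, none or still open, it means among the compounds named here.

Of the compounds shown here, three sharing one core have been measured in a functional assay on HepG2 cells (Homo sapiens) for antiproliferative activity, read by MTT assay, with a stated time of 48 h; on this read-out higher numbers stand for weaker inhibition and lower numbers for stronger inhibition. Compound 1 `O=[N+]([O-])c1ccccc1CSc1nnc(-c2ccc3c(c2)OCCO3)o1` gives 38100 nM, compound 2 `Brc1ccccc1CSc1nnc(-c2ccc3c(c2)OCCO3)o1` gives 20000 nM, and compound 3 `Brc1ccc(CSc2nnc(-c3ccc4c(c3)OCCO4)o2)cc1` gives 8540 nM, the lowest of the three. The cores of compound 2 and compound 3 differ in 4-bromophenyl in place of 2-bromophenyl on a saturated chain carbon bound to a sulfur, and that rearrangement gave a 2.3-fold lower number from compound 2 to compound 3 (0.37 log units; beyond the scatter). Exchanging the halogen, (nitro in place of bromo on an aromatic carbon), gave a 1.9-fold higher number from compound 2 to compound 1 (0.28 log units; within the scatter). Compound 4 `O=[N+]([O-])c1ccc(CSc2nnc(-c3ccc4c(c3)OCCO4)o2)cc1` is not yet measured; it differs from compound 3 by nitro in place of bromo on an aromatic carbon. This is the same kind of change as the earlier one, though not the same: in compound 1 the nitro sits ortho to a large group, in compound 4 para to a large group. Because the earlier exchange gave a 1.9-fold higher number from compound 2 to compound 1 (0.28 log units; within the scatter), compound 4 is expected to shift by about a 1.8-fold higher number from compound 3 to compound 4 (0.24 log units; within the scatter). Compound 4 is therefore estimated at 15000 nM, with a likely range from 6000 nM to 40000 nM.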

Compound 4, half-maximal inhibitory concentration: 35400 nM
Compound 4: the middle estimate sits 2.4-fold (0.37 log units) below what was measured; measured number inside the range.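

Nitro in place of bromo, para to a large group, gave a 4.1-fold higher number from compound 3 to compound 4 (0.62 log units; beyond the scatter) in this assay. Set beside the earlier exchange, this step does not differ from it by more than the scatter allows, so the change carries across the two cores as far as these pairs can tell: the same change on two cores in this assay, a 1.9-fold higher number (0.28 log units; within the scatter) from compound 2 to compound 1 and a 4.1-fold higher number (0.62 log units; beyond the scatter) from compound 3 to compound 4, 2.2-fold (0.34 log units) apart, within the scatter of two such steps. Among these compounds, this rests on only two pairs, and only the newer step lies beyond the scatter, so it does not show that the exchange would raise the number on every core, nor does it show why the number moves. As far as these compounds go, what an amine or a carboxylic acid in place of bromo would give on these cores stays open, as does what a longer chain on the sulfur would do to the number.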